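A methoxy for a methyl on the carbonyl carbon

The compounds below may be only part of what the source reports. "The series", "measured", "known", "first", "only" and "open" are said of these compounds alone.

In a functional assay on the whole organism for antagonist activity, with Mus musculus as the target (on this read-out lower numbers stand for an effect already at smaller amounts and higher numbers for an effect only at larger amounts of compound), compound 1 `CC(=O)N(C)C(C)C#CCn1ccnc1C` gives 0.2 mg/kg. Compound 2 `CC(=O)NCC#CCn1ccnc1` is reported only as a limit, > 100 mg/kg. Compound 3 `CC(=O)NCC#CCn1cncc1C` gives 66 mg/kg, the higher of the two actual numbers, with compound 1 holding the lower one.

Compound 4 `COC(=O)NCC#CCn1cncc1C` departs from compound 3 in one place: methoxy in place of methyl on a carbonyl carbon. That is methoxy in place of methyl on a carbonyl carbon. Among the measured compounds shown here, the only measured step, an at least 1.5-fold lower number from compound 2 to compound 3 (0.18 log units; that floor lies within the scatter), comes from a different change, methyl in place of hydrogen on an aromatic carbon, so it gives no size for this one. For the measured compounds named here, no measured step involves a swap on the carbonyl carbon. A shift beyond the scatter in this assay is therefore not expected in either direction, though the uncertainty is wide. The expected size is a 1.3-fold lower number from compound 3 to compound 4 (0.12 log units; within the scatter). For compound 4 the estimated value is 50 mg/kg, with an expected range from 12 mg/kg to 150 mg/kg.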

Compound 4, dose for half-maximal effect: 80 mg/kg
The estimate for compound 4 lay 1.6-fold (0.20 log units) below the measured number; the range from low to high includes it.
By their numbers in this assay, from the lowest: compound 1; then compounds 3 and 4 (each within the scatter of the next). At a limit, above all of these: compound 2.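

In this assay the swap of methyl for methoxy on a carbonyl carbon whose other neighbour is an amide-type nitrogen gives a step within the scatter (a 1.2-fold higher number from compound 3 to compound 4 (0.08 log units; within the scatter)), so acetamido and (methoxycarbonyl)amino cannot be told apart in this pair. Among the compounds shown here, this is the first reading at this place: the earlier step concerned a methyl on an aromatic carbon, whereas this one shows that an added oxygen and hydrogen-bond acceptor here comes with no shift beyond the scatter. Nothing among the data shown gives a cause for this result.

Going by these compounds, whether an ethoxy group or a dimethylamino group on the same carbonyl carbon would read the same remains open. On these data alone, it is also open whether the methoxy swap would behave alike on the core of compound 1 (0.2 mg/kg).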